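The source may report more compounds than this note shows. Statements on the series, on what has been measured and on what is new or still open speak of the compounds shown alone.

In a functional assay on HL-60 cells (Homo sapiens) for antiproliferative activity, read by XTT assay, with a stated time of 72 h (on this read-out lower numbers stand for stronger inhibition and higher numbers for weaker inhibition), compound 1 (`CNc1ncnc2c1c(-c1ccoc1)cn2[C@@H]1O[C@H](CO)[C@@H](O)[C@H]1O`) gives > 15000 nM, which is a limit of the assay and not a number. Compound 2 (`C#Cc1cn([C@@H]2O[C@H](CO)[C@@H](O)[C@H]2O)c2ncnc(NC)c12`) reads 9060 nM. Among the compounds with values here, the one measured step is an at least 1.6-fold lower number from compound 1 to compound 2 (0.21 log units; that floor lies within the scatter), and it concerns ethynyl in place of furan-3-yl, not the site changed next. Compound 3 (`Cc1ncnc2c1c(-c1ccoc1)cn2[C@@H]1O[C@H](CO)[C@@H](O)[C@H]1O`) keeps the furan-3-yl group and carries methyl in place of methylamino on an aromatic carbon, next to the ring nitrogen: methyl in place of methylamino on an aromatic carbon. Within the data shown here, no measured step touches this site, so the guide is weak. Among the measured compounds shown here, compound 2 at 9060 nM shows only that a small change can bring a readable number in this assay. A modest move towards a lower number is therefore expected, an estimated at least 2.5-fold lower number from compound 1 to compound 3 (0.39 log units; beyond the scatter). For compound 3 the expected value is 6000 nM, with an estimated range of 600 nM to 15000 nM.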

Compound 3, half-maximal inhibitory concentration: > 15000 nM
Compound 3: a limit, no number; the forecaster's own chance of this, stated with the estimate: 35%; middle value at least 2.5-fold (0.39 log units) from the limit.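

The step from compound 1 to compound 3 cannot be read, because each compound gives only a limit and not a number: the limit of > 15000 nM in this assay, at which 2 of the 3 values shown sit. As far as these compounds go, how far methyl in place of methylamino on an aromatic carbon moves the number in this assay stays open.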